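The source may report more compounds than this note shows. Statements on the series, on what has been measured and on what is new or still open speak of the compounds shown alone.

Three compounds share one core and differ only in the group on a saturated chain carbon bound to an aromatic carbon and a saturated chain carbon. In a functional assay on CHO cells for antagonist activity at prostaglandin E2 receptor EP3 subtype (Homo sapiens), read by cAMP accumulation (a higher number here means a weaker inhibitor, a lower number a stronger inhibitor), compound 1 `CC(C)C(c1ccc(-c2ccc3cccc(F)c3c2)[nH]c1=O)N1CCN/C1=N\C#N` gives 38 nM. Compound 2 `Cc1nc(C(c2ccc(-c3ccc4cccc(F)c4c3)[nH]c2=O)C(C)C)[nH]c1C` gives 50 nM. Compound 3 `CC(C)C(c1cnc(N)s1)c1ccc(-c2ccc3cccc(F)c3c2)[nH]c1=O` gives 39 nM, the second highest of the three numbers, with all three inside the scatter of one another. The change to compound 4 `CC(C)C(Cc1nnn[nH]1)c1ccc(-c2ccc3cccc(F)c3c2)[nH]c1=O` is (1H-tetrazol-5-yl)methyl in place of 2-amino-1,3-thiazol-5-yl on a saturated chain carbon bound to an aromatic carbon and a saturated chain carbon. Within the data shown here, two measured steps bear on it: a 1.0-fold higher number from compound 1 to compound 3 (0.01 log units; within the scatter) and a 1.3-fold lower number from compound 2 to compound 3 (0.11 log units; within the scatter). Each earlier swap at this carbon left the number essentially unchanged, so no step beyond the scatter is expected in this assay, though the entering group resembles none of those already tested. For compound 4 the estimate is 60 nM, within a range from 25 nM to 180 nM. The step expected in this assay is a 1.5-fold higher number from compound 3 to compound 4 (0.19 log units; within the scatter).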

Compound 4, half-maximal inhibitory concentration: 134 nM
Compound 4: middle estimate off by 2.2-fold (0.35 log units), on the low side; the measured number falls inside the stated range.
By their numbers in this assay, from the lowest: compounds 1, 3 and 2 (each within the scatter of the next); then compound 4.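

In this assay this saturated chain carbon proves not to be indifferent to its group: with (1H-tetrazol-5-yl)methyl the steps are a 3.4-fold higher number from compound 3 to compound 4 (0.54 log units; beyond the scatter) and a 2.7-fold higher number from compound 2 to compound 4 (0.43 log units; beyond the scatter) and also a 3.5-fold higher number from compound 1 to compound 4 (0.55 log units; beyond the scatter), the first at this place beyond the scatter. The entering and leaving groups of the step from compound 3 match in heavy atoms, donors, acceptors and net charge, so these counts do not separate them. Nothing measured here explains the loss.

From the compounds shown here alone, whether the step follows the tetrazole ring or its methyl link stays open, as the entering group changes both at once. A 1H-tetrazol-5-yl group set directly on this carbon, or a carboxymethyl group, would help to separate the two.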